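Compound 4: (trifluoromethyl)sulfanyl in place of trifluoromethoxy

The source may hold more compounds than are shown below. What is called first, only, known or untested is meant among the compounds shown, and "the series" means these compounds.

Three compounds sharing one core have been run in an ADME assay on HEK293 cells (Homo sapiens) for cytotoxicity, with a stated time of 72 h; on this read-out lower numbers stand for an effect already at smaller amounts and higher numbers for an effect only at larger amounts of compound. Compound 1 (`Cc1cc(NC(=O)Nc2ccc(C(C)(C)C)cc2)c2ccccc2n1`) gives > 25000 nM, which is a limit and not a number. Compound 2 (`Cc1ccc(NC(=O)Nc2cc(C)nc3ccccc23)cc1`) gives > 25000 nM, again a limit. For the measured compounds named here, compound 3 (`Cc1cc(NC(=O)Nc2ccc(OC(F)(F)F)cc2)c2ccccc2n1`) gives 14000 nM, the only true number among the three.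

Compound 4 (`Cc1cc(NC(=O)Nc2ccc(SC(F)(F)F)cc2)c2ccccc2n1`) has not been measured. Its change from compound 3 is (trifluoromethyl)sulfanyl in place of trifluoromethoxy on an aromatic carbon, para to a large group.

The measured steps all concern this same place. They are an at least 1.7-fold lower number from compound 1 to compound 3 (0.25 log units; that floor lies within the scatter) and an at least 1.7-fold lower number from compound 2 to compound 3 (0.25 log units; that floor lies within the scatter), and both of those floors lie within the scatter. The remaining one is a step that the two limits leave unreadable from compound 1 to compound 2. None of them compares the two groups now being exchanged, so they give no direction for the new step and no sign of a large one. Compound 3 at 14000 nM therefore serves as the anchor, and no step beyond the scatter is expected in this assay.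

The expected step is a 1.1-fold lower number from compound 3 to compound 4 (0.03 log units; within the scatter). For compound 4 the estimated value is 13000 nM, with an expected range from 6000 nM to 25000 nM.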

Compound 4, half-maximal effective concentration in the HEK293 assay: 13000 nM
Estimate against measurement, compound 4: no gap at the digits printed; the range from low to high includes it.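

In the HEK293 assay compound 4 gives 13000 nM, so this position now holds a second true number. In the HEK293 assay, the exchange of trifluoromethoxy for (trifluoromethyl)sulfanyl gives a 1.1-fold lower number from compound 3 to compound 4 (0.03 log units; within the scatter), so the two groups cannot be told apart on this read-out. In a physicochemical assay for solubility, at pH 7.4 (on this read-out lower numbers stand for lower solubility and higher numbers for higher solubility), compound 3 gives 300 nM and compound 4 gives 200 nM. In the physicochemical assay, the same exchange gives a 1.5-fold lower number from compound 3 to compound 4 (0.18 log units; within the scatter), so the two groups cannot be told apart there either. In the HEK293 assay, the steps from the two compounds held at a limit are floors only, an at least 1.9-fold lower number from compound 2 to compound 4 (0.28 log units; that floor lies within the scatter) and an at least 1.9-fold lower number from compound 1 to compound 4 (0.28 log units; that floor lies within the scatter), so no difference from methyl or tert-butyl is established, and the true size of these steps stays unreadable because the comparison ends at a limit: the limit of > 25000 nM in the HEK293 assay, at which 2 of the 4 values shown sit.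

From the compounds shown here alone, it remains open whether any group at this place, such as an amine or a carboxylic acid, would move the number in the HEK293 assay beyond the scatter. Going by these compounds, it also remains open whether such a group, or a longer chain in place of the methyl on the shared core, would separate the compounds in the physicochemical assay.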